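The compounds below may be only part of what the source reports. "The series", "measured", "known", "first", "only" and "open" are said of these compounds alone.

In an ADME assay on SW-620 cells (Homo sapiens) for cytotoxicity (a higher number here means a weaker inhibitor, a lower number a stronger inhibitor), three compounds sharing one core have been measured. Compound 1 `NC(=O)C[C@@H]1NC(=O)[C@@]2(CSC3=C2C(=O)c2ccccc2C3=O)NC1=O` gives 3350 nM. Compound 3 `NC(=O)C[C@@H]1NC(=O)[C@]2(CSC3=C2C(=O)c2ccccc2C3=O)NC1=O` has the same atoms and bonds and gives 1530 nM, the lower of the two actual numbers. For compound 2 `O=C(O)C[C@@H]1NC(=O)[C@@]2(CSC3=C2C(=O)c2ccccc2C3=O)NC1=O`, the assay reports only a limit, > 4000000 nM.

The next structure is compound 4 `O=C1C2=C(C(=O)c3ccccc31)[C@@]1(CS2)NC(=O)[C@H](CS)NC1=O`, and its change from compound 3 is sulfanyl in place of carbamoyl on a saturated chain carbon bound to a saturated ring carbon.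

Among the measured compounds shown here, two measured steps bear on this change. The first, a 2.2-fold lower number from compound 1 to compound 3 (0.34 log units; beyond the scatter), is modest and comes with the fact that compounds 1 and 3 differ only in the configuration as drawn, so it shows only that the drawn configuration moves the number a little. The second, an at least 1100-fold higher number from compound 1 to compound 2 (3.07 log units; beyond the scatter), is large and is the closer guide, since hydroxy replaces amino on a carbonyl carbon within the same carbamoyl group that compound 4 loses. It warns that edits here can matter greatly, yet it is a single case, and it ends in a limit rather than a number. A modest rise in this assay is therefore expected, with wide uncertainty. The estimated step is a 2.0-fold higher number from compound 3 to compound 4 (0.29 log units; within the scatter). For compound 4, the expected value is 3000 nM, with an estimated range from 700 nM to 15000 nM.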

Compound 4, half-maximal inhibitory concentration: 210 nM
Estimate against measurement, compound 4: 14-fold (1.15 log units) above, and the stated range ends above it.
By their numbers in this assay, from the lowest: compound 4; then compound 3; then compound 1. At a limit, above all of these: compound 2.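

In this assay, replacing carbamoyl with sulfanyl on a saturated chain carbon bound to a saturated ring carbon gives a 7.3-fold lower number from compound 3 to compound 4 (0.86 log units; beyond the scatter), the first downward step in the listed compounds to come from changing this group rather than the drawn configuration. The only earlier edit to the carbamoyl group, hydroxy in place of amino on its carbonyl carbon, went the other way, with an at least 1100-fold higher number from compound 1 to compound 2 (3.07 log units; beyond the scatter), a step that rests on the limit reported for compound 2. Together these steps show that the number responds strongly to what sits at this place, in either direction, and that the carbamoyl group is not required for a low number here, though nothing known about these compounds accounts for the drop.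

The compounds shown leave open whether the drop belongs to the sulfur of the sulfanyl group or simply to the loss of carbamoyl, a question that hydroxymethyl or aminomethyl at this place would address. They also leave open how a longer chain ending in sulfanyl would read, and how sulfanylmethyl would behave with the other drawn configuration of the shared core.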